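This account rests on a few compounds, and the source may have more. Where it says the series, first, only, none or still open, it means among the compounds named here.

Working notes on the series, all members sharing the core of compound 1 (`CC1=CC[C@H]2[C@H](CC[C@]2(C)O)C(C)(C)[C@@H]1CC[C@H]1[C@]2(C)CC[C@H](OC(=O)c3ccc(F)cc3)C(C)(C)O[C@H]2CC[C@@]1(C)O`). In a functional assay on MDA-MB-231 cells (Homo sapiens) for antiproliferative activity, read by MTT assay, with a stated time of 72 h (a higher number here means a weaker inhibitor, a lower number a stronger inhibitor), compound 1 gives 11300 nM. Within the data shown here, compound 2 (`CC1=CC[C@H]2[C@H](CC[C@]2(C)O)C(C)(C)[C@@H]1CC[C@H]1[C@]2(C)CC[C@H](OC(=O)c3ccccc3C(F)(F)F)C(C)(C)O[C@H]2CC[C@@]1(C)O`) gives 31500 nM, the higher of the two numbers so far, which places it at the weak end of this very small set. Compound 3 (`CC1=CC[C@H]2[C@H](CC[C@]2(C)O)C(C)(C)[C@@H]1CC[C@H]1[C@]2(C)CC[C@H](OC(=O)c3ccc([N+](=O)[O-])o3)C(C)(C)O[C@H]2CC[C@@]1(C)O`) is still unmeasured and differs from compound 2 in one place: 5-nitrofuran-2-yl in place of 2-(trifluoromethyl)phenyl on a carbonyl carbon. In short, 5-nitrofuran-2-yl stands in place of 2-(trifluoromethyl)phenyl on a carbonyl carbon. Among the measured compounds shown here, only one measured step bears on this change: a 2.8-fold higher number from compound 1 to compound 2 (0.45 log units; beyond the scatter), a modest step at the same place, with 2-(trifluoromethyl)phenyl replacing 4-fluorophenyl. For the measured compounds named here, no measured compound carries 5-nitrofuran-2-yl, so the direction is a weakly founded expectation. Compound 2 already holds the higher number at 31500 nM, so a modest step in this assay toward a lower number is expected, close in size to the measured one. The estimated change is a 2.3-fold lower number from compound 2 to compound 3 (0.35 log units; beyond the scatter). For compound 3 the estimated value is 14000 nM, with an expected range of 4500 nM to 40000 nM.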

Compound 3, half-maximal inhibitory concentration: 11100 nM
Beside the measured number, compound 3's estimate is 1.3-fold (0.10 log units) above it; low and high end bracket the measured number.
By their numbers in this assay, from the lowest: compounds 3 and 1 (each within the scatter of the next); then compound 2.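

In this assay, the new result shows that the place on the carbonyl carbon tolerates more than a six-membered aromatic ring of carbon only: 5-nitrofuran-2-yl, a five-membered aromatic ring with 1 hetero atom, gives a 2.8-fold lower number from compound 2 to compound 3 (0.45 log units; beyond the scatter) and so moves clear of the 2-(trifluoromethyl)phenyl compound. The same group cannot be told apart from 4-fluorophenyl, with a 1.0-fold lower number from compound 1 to compound 3 (0.01 log units; within the scatter), so two quite different groups now read alike here, and among these three compounds only compound 2 stands apart, on the weak side. Nothing available bears on what lies behind these numbers.

The compounds shown do not separate the furan ring from its nitro substituent, so a plain furan-2-yl or a 4-nitrophenyl group on the same carbonyl carbon would be needed to tell which part goes with the reading in this assay. Also open, on these data alone, is how this place responds to groups without an aromatic ring, such as a short alkyl chain or a chain ending in an amine, and whether any group here can move the number clearly below the level shared by compound 1 and compound 3.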